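The source may hold more compounds than are shown below. What is called first, only, known or untested is meant among the compounds shown, and "the series" means these compounds.

In a functional assay on SW480 cells (Homo sapiens) for antiproliferative activity, read by MTT assay, with a stated time of 48 h (a lower number here means a stronger inhibitor, a higher number a weaker inhibitor), compound 1 `C=C(CO)C(CCCCC)n1cnc2c(Cl)ncnc21` shows only a limit of the assay (> 50000 nM) and no number. Compound 2 `C=C(CO)C(CCCCCC)n1cnc2c(Cl)ncnc21` gives 32000 nM and compound 3 `C=C(CO)C(CCCCCCC)n1cnc2c(Cl)ncnc21` stands level with it at 29400 nM within the scatter (a 1.1-fold lower number from compound 2 to compound 3 (0.04 log units; within the scatter)). In compound 4 `C=C(CO)C(c1ccccc1)n1cnc2c(Cl)ncnc21` phenyl replaces heptyl on a saturated chain carbon bound to an aromatic nitrogen and a double-bonded chain carbon (phenyl in place of heptyl on a saturated chain carbon bound to an aromatic nitrogen and a double-bonded chain carbon). Among the compounds with values here, no measured step swaps a chain for a ring. Within the data shown here, the only guides are the chain steps (an at least 1.5-fold lower number from compound 1 to compound 2 (0.19 log units; that floor lies within the scatter)) and (an at least 1.7-fold lower number from compound 1 to compound 3 (0.23 log units; that floor lies within the scatter)), whose floors lie within the scatter, so in this assay no step beyond the scatter is expected for compound 4, with a slight lean toward a higher number. The expected step is a 1.4-fold higher number from compound 3 to compound 4 (0.13 log units; within the scatter) here. Compound 4 is estimated at 40000 nM (expected range 18000 nM to 80000 nM) in this reading.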

Compound 4, half-maximal inhibitory concentration: 12900 nM
Estimate against measurement, compound 4: 3.1-fold (0.49 log units) above; the measured number lies below the stated range.
By their numbers in this assay, from the lowest: compound 4; then compounds 3 and 2 (each within the scatter of the next). At a limit, above all of these: compound 1.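

At the saturated chain carbon bound to an aromatic nitrogen and a double-bonded chain carbon, phenyl does better in this assay than the hexyl and heptyl chains (a 2.5-fold lower number from compound 2 to compound 4 (0.39 log units; beyond the scatter); a 2.3-fold lower number from compound 3 to compound 4 (0.36 log units; beyond the scatter)). These are the first steps at this position shown beyond the scatter, so a chain is not needed here for activity. The step against the pentyl compound is only a floor (an at least 3.8-fold lower number from compound 1 to compound 4 (0.58 log units; beyond the scatter)), since compound 1 is held at a limit: the limit of > 50000 nM in this assay, at which 1 of the 4 values shown sits.

As far as these compounds go, whether the gain needs an aromatic ring stays open, and cyclohexyl at this place would test that. Phenyl rings bearing a further group, such as an amine or a methoxy group, also lie outside this set.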